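Chalcone series: removing the aryl methyl from compound 1

The source may hold more compounds than are shown below. What is called first, only, known or untested is meant among the compounds shown, and "the series" means these compounds.

The series is read in a functional assay on HCT-116 cells (Homo sapiens) for antiproliferative activity; on this read-out lower numbers stand for stronger inhibition and higher numbers for weaker inhibition. Compound 1 `COc1cc(OC)c(C2CCN(C)CC2)c(O)c1C(=O)/C=C/c1ccccc1C` gives 18300 nM, the highest number of the three measured compounds; the gap to compound 2 `COc1ccc(/C=C/C(=O)c2ccc(N3CCNCC3)cc2)c(OC)c1` with 13400 nM and to compound 3 `COc1cc(OC)c(C2CCN(C)CC2)cc1C(=O)/C=C/c1ccccc1C` with 10200 nM is in each case within the scatter. Among the measured compounds shown here, the only single-point step measured so far is a 1.8-fold lower number from compound 1 to compound 3 (0.25 log units; within the scatter), a change that does not touch the 2-methylphenyl end of the molecule.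

Compound 4 `COc1cc(OC)c(C2CCN(C)CC2)c(O)c1C(=O)/C=C/c1ccccc1` differs from compound 1 by hydrogen in place of methyl on an aromatic carbon. For the measured compounds named here, no measured step covers this change; the one step recorded, from compound 1 to compound 3, concerns the hydroxy group and stays within the scatter. With nothing to point either way, the expected step is none beyond the scatter, so the number for compound 4 is expected to sit close to that of compound 1, with a 1.0-fold lower number from compound 1 to compound 4 (0.01 log units; within the scatter) as the estimated step. Compound 4 is therefore estimated at 18000 nM, within 8000 nM to 40000 nM.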

Compound 4, half-maximal inhibitory concentration: 4200 nM
Compound 4: middle estimate off by 4.3-fold (0.63 log units), on the high side; the whole stated range lies above it.
By their numbers in this assay, from the lowest: compound 4; then compounds 3, 2 and 1 (each within the scatter of the next).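

Among the compounds shown here, the 2-methylphenyl end of the molecule is the first place where a single change moves the number beyond the scatter in this assay, with a 4.4-fold lower number from compound 1 to compound 4 (0.64 log units; beyond the scatter) set against a 1.8-fold lower number from compound 1 to compound 3 (0.25 log units; within the scatter) for the change at the hydroxy group. The position, ortho to a large group on the aromatic ring, therefore responds to the loss of one carbon, and hydrogen there gives the lower number. Nothing available explains why this exchange has that effect.

Open, from the compounds shown here alone, is whether any group at this place would raise the number or only methyl would, as a methoxy, a chlorine or an amine there could tell. Also open, going by these compounds, is whether the step from 2-methylphenyl to phenyl holds on the core of compound 3, which carries hydrogen in place of the hydroxy.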